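Trifluoromethyl in place of chloro: an expected step

The source may hold more compounds than are shown below. What is called first, only, known or untested is meant among the compounds shown, and "the series" means these compounds.

Compound 1 `Cc1ccc(N(CCN2CCC(OCC(=O)O)CC2)C(=O)c2ccc(F)cc2)cc1` gives 970 nM
Compound 2 `Cc1ccc(N(CCN2CCC(OCC(=O)O)CC2)C(=O)c2cccc(Cl)c2)cc1` gives 100 nM

In a functional assay on a cell-free system (Platelet, plasma, Homo sapiens) for inhibition (a lower number here means a stronger inhibitor, a higher number a weaker inhibitor), compound 2 has the lower of the two numbers (100 nM) measured so far. Compound 3 `Cc1ccc(N(CCN2CCC(OCC(=O)O)CC2)C(=O)c2cccc(C(F)(F)F)c2)cc1` differs from it by trifluoromethyl in place of chloro on an aromatic carbon with trifluoromethyl in place of chloro on an aromatic carbon, meta to a large group. Among the compounds with values here, the only measured step (a 9.7-fold lower number from compound 1 to compound 2 (0.99 log units; beyond the scatter)) changed the halogen and its place together, so it bears on this swap only loosely. No shift beyond the scatter is expected in this assay and the estimated result is a 1.1-fold higher number from compound 2 to compound 3 (0.04 log units; within the scatter) for now. Compound 3 is estimated at 110 nM with an expected range from 35 nM to 350 nM in this assay.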

Compound 3, half-maximal inhibitory concentration: 20000 nM
Estimate against measurement, compound 3: 180-fold (2.26 log units) below, outside the stated range (above it).
By their numbers in this assay, from the lowest: compound 2; then compound 1; then compound 3.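

Trifluoromethyl in place of chloro at the same place gives a 200-fold higher number from compound 2 to compound 3 (2.30 log units; beyond the scatter) in this assay and so shows that this position, meta to a large group, does not treat the two groups alike. Compound 3 also ends up behind the 4-fluorophenyl compound, with a 21-fold higher number from compound 1 to compound 3 (1.31 log units; beyond the scatter) and so the advantage of compound 2 does not carry over to every group placed here. Nothing available explains why this swap costs so much.

The compounds shown leave open whether bromo, methyl or methoxy at this place would stay near compound 2 or fall towards compound 3.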